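The compounds below may be only part of what the source reports. "The series", "measured", "known", "first", "only" and "open" are said of these compounds alone.

In a functional assay on DU-145 cells (Homo sapiens) for inhibition, read by trypan blue exclusion, with a stated time of 96 h (a lower number here means a stronger inhibitor of growth, a higher number a weaker inhibitor of growth), compound 1 `Cc1ccc(S/C(=C/c2ccc(F)c(C)c2)C(=O)c2ccc(Br)cc2)cc1` gives 25000 nM. Compound 2 `O=C(O)c1cc(/C=C(\C(=O)c2c(F)c(F)c(F)c(F)c2F)S(=O)(=O)c2ccc(Br)cc2)ccc1O` reports only a limit of the assay, > 100000 nM. Compound 3 `O=C(O)c1cc(/C=C(/Sc2ccc(Br)cc2)C(=O)c2c(F)c(F)c(F)c(F)c2F)ccc1O` gives 25000 nM, which places it level with compound 1. Putting (4-bromophenyl)sulfanyl in place of (4-bromophenyl)sulfonyl produced an at least 4.0-fold lower number from compound 2 to compound 3 (0.60 log units; beyond the scatter).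

Compound 4 `O=C(/C(=C\c1ccc(O)c(Br)c1)Sc1ccc(Br)cc1)c1c(F)c(F)c(F)c(F)c1F` keeps that sulfanyl group and changes a different place: bromo in place of carboxy on an aromatic carbon. The 3-carboxy-4-hydroxyphenyl of compound 3 thus becomes 3-bromo-4-hydroxyphenyl in compound 4.

Within the data shown here, the one measured step lies elsewhere in the molecule, so it gives no direct guide to the size of this change. The nearest hint is indirect: compound 1 also has no carboxy and gives 25000 nM, although it differs from compound 3 in other places too. A large step therefore seems unlikely, and any shift is expected to be small and towards a lower number. The expected change is a 1.7-fold lower number from compound 3 to compound 4 (0.22 log units; within the scatter). For compound 4, the estimated value is 15000 nM, with an expected range from 4000 nM to 50000 nM.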

Compound 4, concentration for 50% growth inhibition: 1000 nM
Estimate against measurement, compound 4: 15-fold (1.18 log units) above; the whole stated range lies above it.
By their numbers in this assay, from the lowest: compound 4; then compounds 1 and 3 (each within the scatter of the next). At a limit, above all of these: compound 2.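

The position ortho to the hydroxy group turns out to matter a great deal: replacing carboxy with bromo there gives a 25-fold lower number from compound 3 to compound 4 (1.40 log units; beyond the scatter). Until this result, the only step that could be read lay in the sulfur-linked group, so nothing had shown how the aromatic ring bearing the hydroxy group responds to change. Here, a swap of one small group at that ring carbon, with the rest of the molecule unchanged, is enough to produce a large gain in growth inhibition.

Among these compounds, the single swap removes carboxy and adds bromo at once, so a hydrogen, a chloro group or a primary amide at this position would be needed to show whether losing the first or gaining the second drives the step. Nothing measured here accounts for the size of this step.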